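Methoxy on the aryl of compound 3: expected inhibition

The compounds below may be only part of what the source reports. "The series", "measured", "known", "first", "only" and "open" are said of these compounds alone.

The shared core is seen in compound 3 `C/C(=N\O)c1ccc(NC(=O)CSc2nnc(-c3ccccc3)n2-c2ccccc2)cc1`, which in a functional assay on the whole organism (strain albino) for inhibition, with Rattus norvegicus as the target, read by paw edema, with stated times of 30 min and 5 h, at a dose of 0.28 mmol/kg by the oral route (on this read-out higher numbers stand for more inhibition at the one dose given (going by the name of the read-out) and lower numbers for less inhibition), gives 66%. Compound 1 `COc1cc(-c2nnc(SCC(=O)Nc3ccc(/C(C)=N/O)cc3)n2-c2ccccc2)cc(OC)c1OC` gives 70% and compound 2 `C=CCn1c(SCC(=O)Nc2ccc(/C(C)=N/O)cc2)nnc1-c1ccccc1` gives 71%; compound 3 sits within the scatter of both, as a number 4 percentage points lower from compound 1 to compound 3 (within the scatter) and a number 5 percentage points lower from compound 2 to compound 3 (within the scatter) show. Compound 4 `COc1ccc(-c2nnc(SCC(=O)Nc3ccc(/C(C)=N/O)cc3)n2-c2ccccc2)cc1` is not yet measured; it differs from compound 3 by methoxy in place of hydrogen on an aromatic carbon. The step that bears on this is a number 4 percentage points lower from compound 1 to compound 3 (within the scatter), where 3,4,5-trimethoxyphenyl against phenyl on that same ring left the read-out within the scatter; the allyl step concerns another place. For compound 4 the expected step is therefore a number 3 percentage points higher from compound 3 to compound 4 (within the scatter), none beyond the scatter. Compound 4 is estimated at 69%, within 58% to 80%.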

Compound 4, a percentage reported as inhibition, in the whole organism at one dose (the size of the read-out at that dose, not a potency): 58%
For compound 4 the middle estimate is 11 percentage points above the measured one; the measured number falls inside the stated range.
By their numbers in this assay, from the lowest: compounds 4, 3, 1 and 2 (each within the scatter of the next, the first and the last beyond it).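

At this position, the step of a number 8 percentage points lower from compound 3 to compound 4 (within the scatter) in this assay keeps the single methoxy, para to a large group, within the scatter of the unsubstituted phenyl. Among these compounds, the step of a number 12 percentage points lower from compound 1 to compound 4 (beyond the scatter) is the first on this aryl to go beyond the scatter, so the choice of substituents here can matter, although phenyl itself stays within the scatter of both methoxy-bearing aryls. No measured evidence accounts for this difference. On these data alone, what an amine or a carboxylic acid in the same place would give stays open.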